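The source may hold more compounds than are shown below. What is called first, only, known or untested is meant among the compounds shown, and "the series" means these compounds.

Working notes on the series.

Three compounds share a core and differ in the bicyclic group carried on the sulfur or in a substituent on it. Compound 1 `CCCCCCN(CCCCCSc1nc2cc(C)ccc2[nH]1)C(=O)Nc1ccc(F)cc1F` gives 1000 nM in an assay on microsomes from liver for inhibition of sterol O-acyltransferase 1 (Rattus norvegicus); a lower number here means a stronger inhibitor, a higher number a weaker inhibitor. Compound 2 `CCCCCCN(CCCCCSc1nc2cc([N+](=O)[O-])ccc2[nH]1)C(=O)Nc1ccc(F)cc1F` gives 2000 nM in this assay; the nitro in place of methyl on an aromatic carbon gave a 2.0-fold higher number from compound 1 to compound 2 (0.30 log units; within the scatter). Compound 3 `CCCCCCN(CCCCCSc1nc2ccc[nH]c-2n1)C(=O)Nc1ccc(F)cc1F` gives 3600 nM in this assay, the highest number of the three: the exchange of the bicyclic group on the sulfur gave a 3.6-fold higher number from compound 1 to compound 3 (0.56 log units; beyond the scatter) and, from the nitro compound, a 1.8-fold higher number from compound 2 to compound 3 (0.26 log units; within the scatter).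

Compound 4 `CCCCCCN(CCCCCSc1nc2c[nH]cnc-2n1)C(=O)Nc1ccc(F)cc1F` is not yet measured in this assay. Relative to compound 3 the change is again on the sulfur: a group of 9 heavy atoms (5 carbon, 4 nitrogen; one five-membered aromatic ring with 2 hetero atoms, one six-membered aromatic ring with 2 hetero atoms) in place of a group of 9 heavy atoms (6 carbon, 3 nitrogen; one five-membered aromatic ring with 2 hetero atoms, one six-membered aromatic ring with 1 hetero atom), on a sulfur. Within the data shown here, the only steps bearing on such an exchange of the sulfur-bound bicyclic group are the two ending at compound 3, one modest and beyond the scatter, one within it. The same kind of exchange is therefore expected to move the number little, if at all, and more likely upward than downward; the expected step is a 1.5-fold higher number from compound 3 to compound 4 (0.18 log units; within the scatter). For compound 4 in this assay the estimate is 5500 nM, with a range from 2500 nM to 12000 nM.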

Compound 4, half-maximal inhibitory concentration: 860 nM
Compound 4: middle estimate off by 6.4-fold (0.81 log units), on the high side; measured number outside the range, below it.
By their numbers in this assay, from the lowest: compounds 4, 1, 2 and 3 (each within the scatter of the next, the first and the last beyond it).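

At this position a loss of ring carbon does not by itself go with a higher number in this assay: the group with 5 carbon and 4 nitrogen atoms gives a 4.2-fold lower number from compound 3 to compound 4 (0.62 log units; beyond the scatter), opposite in direction to the earlier step, a 3.6-fold higher number from compound 1 to compound 3 (0.56 log units; beyond the scatter). The same group gives a 2.3-fold lower number from compound 2 to compound 4 (0.37 log units; beyond the scatter) and also a 1.2-fold lower number from compound 1 to compound 4 (0.07 log units; within the scatter), so a six-membered aromatic ring of carbon only is not required to reach the level of compound 1, and the higher number of compound 3 is not shared by every group with hetero atoms in that ring. Nothing on hand accounts for the gap between these two groups of equal size on the sulfur.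

Compound 3 and compound 4 alone cannot separate the number of nitrogen atoms in the six-membered ring from where those atoms sit in it. From the compounds shown here alone, it also stays open whether an amine or a carboxylic acid on that six-membered ring would keep the number near that of compound 4 at 860 nM and whether either would instead move it beyond the scatter in either direction.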